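Replacing nitro with pentafluoroethyl on a shared core

This account rests on a few compounds, and the source may have more. Where it says the series, first, only, none or still open, it means among the compounds named here.

Compound 1 `O=C1CCCCN1C1=CC(CF)(CF)Oc2ccc(C(F)(F)C(F)(F)F)cc21` gives 5.62 nM here
Compound 2 `O=c1ccccn1C1=CC(CF)(CF)Oc2ccc(C(F)(F)C(F)(F)F)cc21` gives 2.95 nM here
Compound 3 `O=[N+]([O-])c1ccc2c(c1)C(c1cccc[n+]1[O-])=CC(CF)(CF)O2` gives 1.74 nM here

All three numbers come from a functional assay (aorta) with Rattus norvegicus as the target (a higher number here means that more compound is needed for the effect, a lower number that less compound is needed), and place compound 3 within the scatter of compound 2 but beyond the scatter of compound 1. Among the compounds with values here, compound 4 `[O-][n+]1ccccc1C1=CC(CF)(CF)Oc2ccc(C(F)(F)C(F)(F)F)cc21` keeps the rest of compound 3 and carries 1,1,2,2,2-pentafluoroethyl in place of nitro on an aromatic carbon as its single change.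

Within the data shown here, no measured step tests this exchange directly. Among the measured compounds shown here, the only step available is a 1.9-fold lower number from compound 1 to compound 2 (0.28 log units; within the scatter) and it alters the group on a double-bonded ring carbon while the pentafluoroethyl group stays. For the measured compounds named here, it shows only that these two compounds with that group sit within the scatter of each other. Compound 4 shares its pentafluoroethyl group with compound 2 at 2.95 nM and shares the rest of its structure with compound 3 at 1.74 nM and those two values also lie within the scatter of each other. No step beyond the scatter is therefore expected, though the evidence is indirect. The expected change is a 1.4-fold higher number from compound 3 to compound 4 (0.16 log units; within the scatter) in this assay and remains a tentative estimate. The estimate for compound 4 is 2.5 nM with an expected range from 0.9 nM to 7 nM when measured.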

Compound 4, half-maximal effective concentration: 1.7 nM
For compound 4 the middle estimate is 1.5-fold (0.17 log units) above the measured one; the measured number falls inside the stated range.
By their numbers in this assay, from the lowest: compounds 4, 3, 2 and 1 (each within the scatter of the next, the first and the last beyond it).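

In this assay the exchange on this aromatic carbon can now be read directly, and a 1.0-fold lower number from compound 3 to compound 4 (0.01 log units; within the scatter) shows that 1,1,2,2,2-pentafluoroethyl and nitro cannot be told apart here, even though the entering group has more heavy atoms and no hydrogen-bond acceptors. With pentafluoroethyl held in place, the group on the double-bonded ring carbon now has two further readings: a 1.7-fold lower number from compound 2 to compound 4 (0.24 log units; within the scatter) leaves that pair within the scatter, whereas a 3.3-fold lower number from compound 1 to compound 4 (0.52 log units; beyond the scatter) is a modest step beyond it. The step beyond the scatter thus separates the non-aromatic ring of compound 1 from the aromatic ring of compound 4, but this is no general rule for aromatic rings, since compound 2 also carries an aromatic ring and stays within the scatter of compound 1.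

From the compounds shown here alone, it remains open whether a trifluoromethyl group, a nitrile or an amine on the same aromatic carbon would also match nitro, and whether the match between nitro and pentafluoroethyl holds with other groups on the double-bonded ring carbon. Nothing given here bears on what lies behind these numbers.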